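A few compounds are considered here, and "the series" means these few. Any claim that something is new, unique, unknown or untested is made for them only; others in the source may bear on it.

Two compounds share one core and differ only at the far end of the chain. Compound 1 `O=C(CN1CCN(c2cc3c(cc2F)c(=O)c(C(=O)O)cn3C2CC2)CC1)Nc1ccc(C(=O)/C=C/c2ccccc2)cc1` has hydrogen on the outer aromatic carbon; in a physicochemical assay for solubility, at pH 7.8 (on this read-out lower numbers stand for lower solubility and higher numbers for higher solubility), compound 1 gives 2.53 ug/mL. Compound 2 `O=C(CN1CCN(c2cc3c(cc2F)c(=O)c(C(=O)O)cn3C2CC2)CC1)Nc1ccc(C(=O)/C=C/c2ccc(Cl)cc2)cc1` has chloro there, and in this assay compound 2 gives 2.23 ug/mL. Among the measured compounds shown here, the step of a 1.1-fold lower number from compound 1 to compound 2 (0.05 log units; within the scatter) sits within the scatter, so these two numbers cannot be told apart; compound 2 holds the bottom place of the two numbers in arithmetic only, with compound 1 as its sole neighbour inside the scatter.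

Compound 3 `COc1ccc(/C=C/C(=O)c2ccc(NC(=O)CN3CCN(c4cc5c(cc4F)c(=O)c(C(=O)O)cn5C4CC4)CC3)cc2)cc1OC` has not been measured. Its change from compound 2 is 3,4-dimethoxyphenyl in place of 4-chlorophenyl on a double-bonded chain carbon bound to a double-bonded chain carbon. For the measured compounds named here, the single measured step, a 1.1-fold lower number from compound 1 to compound 2 (0.05 log units; within the scatter), concerns a different exchange on that ring and was flat; no measured pair covers the entry of two methoxy groups, and nothing in the data points in either direction. A step of a 1.1-fold higher number from compound 2 to compound 3 (0.05 log units; within the scatter) is therefore expected, meaning none beyond the scatter. Compound 3 is estimated at 2.5 ug/mL, with a likely range from 0.9 ug/mL to 7 ug/mL.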

Compound 3, solubility: 0.68 ug/mL
For compound 3 the middle estimate is 3.7-fold (0.57 log units) above the measured one; the whole stated range lies above it.
By their numbers in this assay, from the lowest: compound 3; then compounds 2 and 1 (each within the scatter of the next).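

The ring at the end of the chain, on a double-bonded chain carbon bound to a double-bonded chain carbon, now proves able to move the read-out in this assay: swapping hydrogen for chloro there gave two numbers that could not be told apart, but 3,4-dimethoxyphenyl in place of 4-chlorophenyl gives a real drop (a 3.3-fold lower number from compound 2 to compound 3 (0.52 log units; beyond the scatter)). Measured against plain phenyl, the same ring gives a drop of similar size (a 3.7-fold lower number from compound 1 to compound 3 (0.57 log units; beyond the scatter)), so the finding does not rest on a single comparison, although both comparisons share compound 3 and the two reference compounds sit within the scatter of each other. No measurement at hand explains why the number falls with this exchange.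

Both methoxy groups enter together, so these compounds cannot show whether one methoxy group alone would give the same drop or whether it takes the pair. On these data alone, it also remains open how the number would respond to a different kind of group on this ring, such as a hydroxyl group, an amine or a carboxylic acid.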